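Dihydropyridine series: bromo-nitro phenyl replacing difluorophenyl

A few compounds are considered here, and "the series" means these few. Any claim that something is new, unique, unknown or untested is made for them only; others in the source may bear on it.

Working notes on two measured compounds and one not yet measured. Compound 1 `CCOC(=O)C1=C(C)NC(C)=C(C(=O)OCC)C1c1c(-c2ccc(F)cc2)nc2sccn12` gives 1650 nM in an ADME assay on Right cardiac atrium (Cavia porcellus); a higher number here means that more compound is needed for the effect, a lower number that less compound is needed. Compound 2 `CCOC(=O)C1=C(C)NC(C)=C(C(=O)OCC)C1c1c(-c2ccc(F)c(F)c2)nc2sccn12` gives 100 nM in this assay, the lowest of the two numbers shown; its nearest neighbour is compound 1. Among the compounds with values here, the measured step of a 17-fold lower number from compound 1 to compound 2 (1.22 log units; beyond the scatter) is the only one available and it changes the same phenyl ring that compound 3 alters.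

Compound 3 `CCOC(=O)C1=C(C)NC(C)=C(C(=O)OCC)C1c1c(-c2ccc(Br)c([N+](=O)[O-])c2)nc2sccn12` is still unmeasured. It differs from compound 2 by 4-bromo-3-nitrophenyl in place of 3,4-difluorophenyl on an aromatic carbon. Within the data shown here, the step from compound 1 to compound 2 shows that a second substituent on this ring moved the number substantially downward, but that step swapped hydrogen for fluoro, whereas compound 3 introduces bromo and nitro in place of both fluorines; no measured pair covers such a swap, so the direction is uncertain and the expected step is small against the uncertainty. Compound 3 is therefore expected to give 300 nM in this assay, with a range of 60 nM to 1500 nM. This estimate means a step of a 3.0-fold higher number from compound 2 to compound 3 (0.48 log units; beyond the scatter).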

Compound 3, half-maximal effective concentration: 4.3 nM
For compound 3 the middle estimate is 70-fold (1.84 log units) above the measured one; the measured number lies below the stated range.
By their numbers in this assay, from the lowest: compound 3; then compound 2; then compound 1.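

At this position, on the aromatic carbon of the five-membered aromatic ring, low numbers in this assay do not require fluoro on the phenyl ring: 4-bromo-3-nitrophenyl in place of 3,4-difluorophenyl gives a 23-fold lower number from compound 2 to compound 3 (1.37 log units; beyond the scatter) and continues the downward direction seen with the added fluoro in a 17-fold lower number from compound 1 to compound 2 (1.22 log units; beyond the scatter) on the same ring. Measured against 4-fluorophenyl, the same group gives a 380-fold lower number from compound 1 to compound 3 (2.58 log units; beyond the scatter) and shows that changes confined to this one phenyl ring, with the rest of the shared core held constant, span a very wide range of numbers in this series. Nothing on hand bears on why the number falls so far with this change.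

Bromo and nitro enter together, so the three compounds cannot show whether either group alone carries the step, or whether both are needed; 4-bromophenyl and 3-nitrophenyl would separate the two. As far as these compounds go, it also remains open whether the low number depends on nitro specifically or would persist with a nitrile, a trifluoromethyl or an amine in its place on the ring.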